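Epoxide for hydroxyenyl side chain on a diterpenoid acid

A few compounds are considered here, and "the series" means these few. Any claim that something is new, unique, unknown or untested is made for them only; others in the source may bear on it.

Measured compounds in a functional assay on SMMC-7721 cells (Homo sapiens) for cytotoxicity, read by MTT assay, with a stated time of 48 h; a higher number here means a weaker inhibitor, a lower number a stronger inhibitor:
compound 1, `C=C1CC[C@@H]2[C@](C)(CCC[C@]2(C)C(=O)O)[C@H]1CC/C(C)=C/CO`: > 40000 nM
compound 2, `C=C/C(C)=C/C[C@H]1C(=C)CC[C@@H]2[C@]1(C)CCC[C@]2(C)C=O`: > 40000 nM

Compound 1 carries a 4-hydroxy-2-methylbut-2-en-1-yl side chain and a carboxylic acid on the shared core. In this assay compound 1 gives only a limit, > 40000 nM, not a number. Compound 2, with an aldehyde in place of the acid and an unsaturated diene chain, likewise returns only a limit, > 40000 nM. Both values therefore rest at the same point, (the limit of > 40000 nM in this assay, at which 2 of the 2 values shown sit), so compound 1 cannot be placed relative to compound 2 on the numbers shown; neither is resolved by the assay.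

Compound 3, `C=C[C@]1(C)O[C@H]1C[C@H]1C(=C)CC[C@@H]2[C@]1(C)CCC[C@]2(C)C(=O)O`, differs from compound 1 by a group of 6 heavy atoms (5 carbon, 1 oxygen; one three-membered non-aromatic ring with 1 hetero atom) in place of a group of 6 heavy atoms (5 carbon, 1 oxygen; no ring), on a saturated chain carbon bound to a saturated ring carbon.

Among the compounds with values here, no measured step between two resolved compounds exists, so there is no measured precedent for how this change moves the half-maximal inhibitory concentration. With both measured compounds sitting at the limit, the expectation for compound 3 is that the step that the limit leaves unreadable from compound 1 to compound 3 is none beyond the scatter, and that compound 3 most likely again sits near or beyond the limit. Compound 3 is expected to give about 45000 nM, within 15000 nM to 130000 nM.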

Compound 3, half-maximal inhibitory concentration: > 40000 nM
Compound 3 ended at the assay's limit; the forecaster's own chance of this, stated with the estimate: 70%; the middle value does not contradict the limit.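

In this assay compound 3 gives > 40000 nM, a limit and not a number. No step from compound 1 to compound 3 can be read, since the values of both are limits: the limit of > 40000 nM in this assay, at which 3 of the 3 values shown sit.

Still open, going by these compounds, is whether the three-membered ring group of compound 3, in place of the 4-hydroxy-2-methylbut-2-en-1-yl chain of compound 1, moves the half-maximal inhibitory concentration at all.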